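This account rests on a few compounds, and the source may have more. Where it says the series, first, only, none or still open, it means among the compounds named here.

Three compounds have a number or a limit in an ADME assay on MDBK cells (Bos taurus) for cytotoxicity, read by MTT assay, with a stated time of 96 h; on this read-out higher numbers stand for lower toxicity in this test and lower numbers for higher toxicity in this test. Compound 1 `COc1ccc(-c2nc3cc(C(F)(F)F)ccc3[nH]2)c(N)c1` gives 4000 nM in this assay, the lower of the two plain numbers, so among them it is the more toxic. Compound 2 `O=C(CN1CCCCC1)Nc1ccc(-c2nc3ccccc3[nH]2)cc1` gives 18000 nM in this assay, a difference from compound 1 that lies beyond the usual scatter. Compound 3 `COc1ccc(-c2nc3cc(C(C)=O)ccc3[nH]2)c(OC)c1` reaches only > 100000 nM in this assay, which is a limit of the measurement and not a number (the limit of > 100000 nM in this assay, at which 1 of the 3 values shown sits).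

Compound 4 `COc1ccc(-c2nc3cc(C(F)(F)F)ccc3[nH]2)cc1` has not yet been measured. It differs from compound 1 in one place: hydrogen in place of amino on an aromatic carbon. Within the data shown here, nothing else in the shared core changes, and no measured pair here shows the effect of that change on its own.

Losing the amino group is expected to move the number only slightly, if at all, toward lower toxicity, so the step of a 1.5-fold higher number from compound 1 to compound 4 (0.18 log units; within the scatter) is estimated to stay within the scatter of this assay. Compound 4 is therefore expected to give about 6000 nM in this assay, with a likely range from 1500 nM to 30000 nM.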

Compound 4, half-maximal cytotoxic concentration: > 100000 nM
Compound 4: no number, only a limit (the forecaster's own chance of this, stated with the estimate: 10%); at least 16-fold (1.22 log units) between middle value and limit.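

In this assay, replacing the amino group on this aromatic carbon with hydrogen gives an at least 25-fold higher number from compound 1 to compound 4 (1.39 log units; beyond the scatter). Among these compounds, this is the first pair here that differs in one place only, and it shows that a single amino group, ortho to a large group, can separate a clearly measurable toxicity from none that can be given a number in this test. Compound 4 gives > 100000 nM, which is a limit of the assay and not a number, so the true size of the step cannot be read: the limit of > 100000 nM in this assay, at which 2 of the 4 values shown sit.

Whether the amino group is special or other groups at this place would act alike stays open, as a hydroxyl group, a methyl group or an acetylated amine is not among the compounds shown. Also open, as far as these compounds go, is whether the same swap would matter as much with a group other than trifluoromethyl on the shared core.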